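The source may hold more compounds than are shown below. What is called first, only, known or untested is meant among the compounds shown, and "the series" means these compounds.

Compound 1 `O=c1cc(CSC(=S)N2CCCC2)oc2ccccc12`: 23400 nM
Compound 2 `O=c1cc(CSC(=S)N2CCCC2)oc2cc(Cl)ccc12`: > 25000 nM
Compound 3 `COc1ccc2oc(CSC(=S)N(C(C)C)C(C)C)cc(=O)c2c1`: 7200 nM

In a functional assay on SW480 cells (Homo sapiens) for antiproliferative activity, read by MTT assay, with a stated time of 72 h (a lower number here means a stronger inhibitor, a higher number a weaker inhibitor), compound 1 gives 23400 nM and stands at the highest of the two numbers this set provides; its nearest neighbour is compound 3, whose 7200 nM lies lower by a margin beyond the scatter. Compound 2 reaches only a limit of the assay, > 25000 nM, and yields no number.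

Compound 4 `O=c1c(Cl)c(CSC(=S)N2CCCC2)oc2ccccc12` has not yet been measured. It differs from compound 1 in one place: chloro in place of hydrogen on an aromatic carbon. One measured step carries the same kind of exchange, chloro in place of hydrogen on an aromatic carbon, though on the other ring of the shared core: the step of an at least 1.0-fold higher number from compound 1 to compound 2 (0.02 log units; that floor lies within the scatter). On these data alone, that step rests on a limit (the limit of > 25000 nM in this assay, at which 1 of the 3 values shown sits), so its true size is unknown; what it does show is no sign of a lower number. On that basis the same exchange on the oxygen-containing ring is expected to leave the number within the scatter of compound 1, with a real chance that compound 4 also reaches only a limit. Compound 4 is therefore estimated at 22000 nM, in the range 9000 nM to 50000 nM, which means an expected step of a 1.1-fold lower number from compound 1 to compound 4 (0.03 log units; within the scatter).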

Compound 4, half-maximal inhibitory concentration: 1400 nM
For compound 4 the middle estimate is 16-fold (1.20 log units) above the measured one; the measured number lies below the stated range.
By their numbers in this assay, from the lowest: compound 4; then compound 3; then compound 1. At a limit, above all of these: compound 2.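

In this assay the exchange gives a 17-fold lower number from compound 1 to compound 4 (1.22 log units; beyond the scatter), so a single chloro in place of hydrogen, on an aromatic carbon of the six-membered aromatic ring with 1 oxygen and two atoms from the ring oxygen, is enough to carry the number well beyond the scatter. The earlier chloro exchange, on the other ring of the shared core, had shown no sign of a lower number, so in this pair of compounds the same atom does not act alike at the two places, and the place decides the outcome. Compound 2 stands only at a limit, > 25000 nM, so its step cannot be read and the gap between the two chloro steps has no size: the limit of > 25000 nM in this assay, at which 1 of the 4 values shown sits.

On these data alone, what stays open is whether the lower number belongs to chloro itself or would also come with another group at this place, such as fluoro, bromo, methyl or methoxy. Also open, as far as these compounds go, is whether the same exchange would give a step of like size on compound 3, which carries a different amine and a methoxy group.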